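A Bromopyridine Replaces a Fluorophenyl on the Thiourea Side Chain

The source may hold more compounds than are shown below. What is called first, only, known or untested is meant among the compounds shown, and "the series" means these compounds.

In a functional assay on HepG2 cells (Homo sapiens) for cytotoxicity, read by MTT assay, with a stated time of 72 h (on this read-out higher numbers stand for weaker inhibition and lower numbers for stronger inhibition), compound 1 `Nc1ccccc1NC(=O)c1ccc(NC(=S)NCc2ccccc2F)cc1` gives 5400 nM. This is the highest of the three numbers available, although compound 2 `Nc1ccccc1NC(=O)c1ccc(NC(=O)NCc2cccnc2)cc1`, at 5100 nM, lies within the scatter of it. Compound 3 `Nc1ccccc1NC(=O)c1ccc(NC(=O)NCc2ccc(Cl)nc2)cc1` gives 2400 nM, a clearly lower number than that of compound 1.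

The next compound, compound 4 `Nc1ccccc1NC(=O)c1ccc(NC(=S)NCc2cncc(Br)c2)cc1`, differs from compound 1 at one place: 5-bromopyridin-3-yl in place of 2-fluorophenyl on a saturated chain carbon bound to an amide-type nitrogen. In words, 5-bromopyridin-3-yl stands in place of 2-fluorophenyl on a saturated chain carbon bound to an amide-type nitrogen.

Within the data shown here, no measured step covers this exchange directly. The nearest guide is a 2.1-fold lower number from compound 2 to compound 3 (0.33 log units; beyond the scatter), a modest change with chloro in place of hydrogen on an aromatic carbon. That step comes from a different halogen and from compounds that carry a carbonyl where compound 1 has a thiocarbonyl, so it transfers only loosely. The close values of compound 1 and compound 2 offer no sign of a large shift with a pyridine ring alone.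

A modest move towards stronger inhibition in this assay is therefore expected, with the estimated change being a 1.8-fold lower number from compound 1 to compound 4 (0.26 log units; within the scatter). For compound 4 the expected value is 3000 nM, with an estimated range from 1300 nM to 6800 nM.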

Compound 4, half-maximal inhibitory concentration: 7500 nM
Compound 4: the middle estimate sits 2.5-fold (0.40 log units) below what was measured; the whole stated range lies below it.
By their numbers in this assay, from the lowest: compound 3; then compounds 2, 1 and 4 (each within the scatter of the next).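

In this assay, the exchange of 2-fluorophenyl for 5-bromopyridin-3-yl on a saturated chain carbon bound to an amide-type nitrogen gives a 1.4-fold higher number from compound 1 to compound 4 (0.14 log units; within the scatter) and so produces no change that can be told apart from the scatter, even though both the ring and the halogen differ. This position therefore accepts a bromine-bearing pyridine in a compound with a thiocarbonyl without a readable loss or gain, whereas the chloro exchange in the carbonyl pair gave a 2.1-fold lower number from compound 2 to compound 3 (0.33 log units; beyond the scatter) and went beyond the scatter. No evidence on hand bears on why these two exchanges read differently.

Among these compounds, the single step does not separate the contribution of the ring nitrogen from that of the bromine, and it leaves open how 5-bromopyridin-3-yl would read with a carbonyl in place of the thiocarbonyl. Also open, going by these compounds, is whether a morpholine, a carboxylic acid or a longer chain at this place would move the number beyond the scatter in either direction.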